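The source may report more compounds than this note shows. Statements on the series, on what has been measured and on what is new or still open speak of the compounds shown alone.

In a functional assay on MCF7 cells (Homo sapiens) for antiproliferative activity, read by MTT assay, with a stated time of 24 h (on this read-out higher numbers stand for weaker inhibition and lower numbers for stronger inhibition), compound 1 (`CCn1c(C(=O)N[C@H](C)CO)ccc1C(CC)(CC)c1ccc(OCS(=O)(=O)c2ccccc2)c(C)c1`) gives 10600 nM and compound 2 (`CCn1c(C(=O)N[C@@H](C(=O)O)C(C)C)ccc1C(CC)(CC)c1ccc(OCS(=O)(=O)c2ccccc2)c(C)c1`) gives 44700 nM as the higher of the two numbers, so compound 2 is the weaker inhibitor of this pair. Compound 3 (`CCn1c(C(=O)N[C@@H](CC(=O)O)C(=O)O)ccc1C(CC)(CC)c1ccc(OCS(=O)(=O)c2ccccc2)c(C)c1`) has not yet been measured. It differs from compound 2 by 1,2-dicarboxyethyl in place of 1-carboxy-2-methylpropyl on an amide-type nitrogen in having 1,2-dicarboxyethyl in place of 1-carboxy-2-methylpropyl on an amide-type nitrogen. Going by the values given here, only one measured step bears on this change, the modest 4.2-fold higher number from compound 1 to compound 2 (0.63 log units; beyond the scatter) at the same nitrogen, and it involves a different exchange. Going by that single upward step, a small further rise is expected in this assay and it may not exceed the scatter. The estimated move is a 1.5-fold higher number from compound 2 to compound 3 (0.16 log units; within the scatter) on this evidence. For compound 3 the expected value is 65000 nM with an estimated range from 25000 nM to 170000 nM around it.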

Compound 3, half-maximal inhibitory concentration: > 50000 nM
Compound 3: a limit, no number; the forecaster's own chance of this, stated with the estimate: 20%; the middle value lies beyond the limit too.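

In this assay compound 3 yields a limit and no number: the limit of > 50000 nM in this assay, at which 1 of the 3 values shown sits.
Placing 1,2-dicarboxyethyl on the amide-type nitrogen in place of 1-carboxy-2-methylpropyl gives an at least 1.1-fold higher number from compound 2 to compound 3 (0.04 log units; that floor lies within the scatter), so this floor does not separate the two groups. Placing it there in place of 1-(hydroxymethyl)ethyl gives an at least 4.7-fold higher number from compound 1 to compound 3 (0.67 log units; beyond the scatter), which shows that the second carboxylic acid does not bring the number back down, and both carboxylic acid-bearing groups stay on the weaker side of the hydroxyl-bearing group of compound 1.

As far as these compounds go, how far compound 3 lies past its limit stays open, and with it the true size of the change from 1-carboxy-2-methylpropyl. From the compounds shown here alone, it is also open whether an amine or a methyl ester on this chain would move the number back towards that of compound 1.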